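A few compounds are considered here, and "the series" means these few. Any claim that something is new, unique, unknown or untested is made for them only; others in the source may bear on it.

Measured in an assay on HEK293 cells for antagonist activity at transient receptor potential cation channel subfamily V member 2 (Rattus norvegicus), read by fluorescence and calcium flux, with a stated time of 5 min; on this read-out lower numbers stand for stronger inhibition and higher numbers for weaker inhibition:
- compound 1, `CCCCCCCCCCCCCCCC[Se]CCC(=O)NCc1ccc(O)c(OC)c1`: 4300 nM
- compound 2, `CCCCCCCC/C=C\CCCCCCCCSC[C@H](N)C(=O)NCc1ccc(O)c(OC)c1`: 1900 nM
- compound 3, `CCCCCCCCCCCCCCCC[Se]C[C@H](N)C(=O)NCc1ccc(O)c(OC)c1`: 1200 nM

Among these three numbers compound 1 stands highest, that is, weakest on this read-out. Its nearest neighbour is compound 2, already beyond the scatter from it, and its furthest is compound 3. For the measured compounds named here, the one step in which two measured compounds differ in a single place is a 3.6-fold lower number from compound 1 to compound 3 (0.55 log units; beyond the scatter), a modest gain brought by an amino group on the chain carbon bound to the carbonyl.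

Compound 4, `CCCCCCCC/C=C\CCCCCCCC[Se]CCC(=O)NCc1ccc(O)c(OC)c1`, has not yet been measured in this assay. It differs from compound 1 by dec-1-en-1-yl in place of octyl on a saturated chain carbon, eight bonds along the chain from a selenium atom. Going by the values given here, no measured pair isolates this chain change. Compounds 2 and 3 carry the two different chains, but they also differ in the atom that links the chain; compound 2 gives 1900 nM and compound 3 gives 1200 nM, and these two values lie within the usual scatter of each other. The data therefore give no sign that lengthening and unsaturating the chain moves the number by itself, and the step from compound 1 to compound 4 is expected to stay within the scatter, in either direction. The estimate for compound 4 in this assay is 3500 nM, expected to fall between 1500 nM and 8500 nM, which means an expected step of a 1.2-fold lower number from compound 1 to compound 4 (0.09 log units; within the scatter).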

Compound 4, half-maximal inhibitory concentration: 1800 nM
Estimate against measurement, compound 4: 1.9-fold (0.29 log units) above; measured number inside the range.
By their numbers in this assay, from the lowest: compounds 3, 4 and 2 (each within the scatter of the next); then compound 1.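

In this assay, for the compounds shown here, the change of octyl to dec-1-en-1-yl, on a saturated chain carbon eight bonds along the chain from a selenium atom, gives the first direct reading of this position (a 2.4-fold lower number from compound 1 to compound 4 (0.38 log units; beyond the scatter)). With the selenium atom and the rest of compound 1 held fixed, the number responds to the far end of the chain by a step beyond the scatter, which the pair of compound 2 and compound 3 could not show, as those two also differ in the linking atom. Compound 1 now has two single changes that lower its number, this one and the amino group on the chain carbon bound to the carbonyl (a 3.6-fold lower number from compound 1 to compound 3 (0.55 log units; beyond the scatter)), but nothing available here accounts for either step.

The change to dec-1-en-1-yl adds both chain length and a double bond, so the step cannot be assigned to either one alone; a saturated decyl chain would separate the two. Going by these compounds, it also remains open how the amino group and the dec-1-en-1-yl chain behave together on the selenium-linked core, and whether a longer chain or a shorter one would move the number further.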